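Two weak inhibitors measured, one analogue still untested

The compounds below may be only part of what the source reports. "The series", "measured", "known", "first", "only" and "open" are said of these compounds alone.

Compound 1 `N#CC1=C(N)Oc2c(c3nc4ccccc4nc3c3ccccc23)C12C(=O)N(Cc1cnnn1-c1ccc(Cl)cc1)c1ccccc12` and compound 2 `N#CC1=C(N)Oc2c(N)cc3nc4ccccc4nc3c2C12C(=O)N(Cc1cnnn1-c1ccccc1Br)c1ccccc12` share a large common core and were both tested in an ADME assay on HUVEC cells (Homo sapiens) for antiproliferative activity, read by MTT assay, with a stated time of 48 h; a higher number here means a weaker inhibitor, a lower number a stronger inhibitor. For compound 1 the result is a limit of the assay rather than a number, > 50000 nM, which matches (the limit of > 50000 nM in this assay, at which 1 of the 2 values shown sits). In this assay compound 2 gives 34200 nM, the only actual number among the two results shown. Among the compounds with values here, compound 1 and compound 2 differ in more than one place, so no single structural step between them can be read, and this set holds no measured step at all.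

Compound 3 `Cc1ccc(-n2nncc2CN2C(=O)C3(C(C#N)=C(N)Oc4c(N)cc5nc6ccccc6nc5c43)c3ccccc32)cc1C` has not yet been measured in this assay. It differs from compound 2 by 3,4-dimethylphenyl in place of 2-bromophenyl on an aromatic nitrogen. Within the data shown here, with no measured step in this set to point either way, the step of a 1.0-fold higher number from compound 2 to compound 3 (0.01 log units; within the scatter) is expected to stay within the usual scatter, with no clear direction. Compound 3 is therefore estimated at 35000 nM, with a likely range from 12000 nM to 100000 nM.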

Compound 3, half-maximal inhibitory concentration: > 50000 nM
Compound 3 was reported as a limit; the forecaster's own chance of this, stated with the estimate: 40%; middle value at least 1.4-fold (0.15 log units) from the limit.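

In this assay, replacing 2-bromophenyl with 3,4-dimethylphenyl on the aromatic nitrogen gives an at least 1.4-fold higher number from compound 2 to compound 3 (0.16 log units; that floor lies within the scatter). Within the data shown here, this is the first step in the set that can be read, but it has only a floor: the true size could lie within the scatter or well beyond it, so the data do not show that this change costs activity. The result for compound 3 is a limit of the assay rather than a number, and the position gains no strong inhibitor, with the limit now holding most of the results: the limit of > 50000 nM in this assay, at which 2 of the 3 values shown sit.

Neither aryl group at this position brings the number anywhere near a strong inhibitor, and with so many results at the limit, the set cannot rank the groups tried or show how much this position matters. Still open, as far as these compounds go, is whether an unsubstituted phenyl, or a ring carrying an amine or a carboxylic acid, would give a measurable and lower number here, and whether the ortho-free pattern of a 4-bromophenyl would differ from the 2-bromophenyl of compound 2.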